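Swapping the (piperidin-1-yl)methyl group of compound 3

This account rests on a few compounds, and the source may have more. Where it says the series, first, only, none or still open, it means among the compounds named here.

In a functional assay on HCT-116 cells (Homo sapiens) for cytotoxicity, read by MTT assay, with a stated time of 72 h (a higher number here means a weaker inhibitor, a lower number a stronger inhibitor), compound 1 (`COc1ncc(-c2ccc3nc(NC(=O)N4CCCC4)nn3c2)cc1NS(=O)(=O)c1ccc(F)cc1`) reads 1290 nM and compound 2 (`COc1ncc(-c2ccc3nc(NC(=O)N(C)C)nn3c2)cc1NS(=O)(=O)c1ccc(F)cc1`) reads 760 nM while compound 3 (`COc1ncc(-c2ccc3nc(NC(=O)NCCN4CCCCC4)nn3c2)cc1NS(=O)(=O)c1ccc(F)cc1`) reads 150 nM as the lowest of the three numbers. Compound 4 (`COc1ncc(-c2ccc3nc(NC(=O)NCC(=O)N4CCOCC4)nn3c2)cc1NS(=O)(=O)c1ccc(F)cc1`) has not yet been measured. It differs from compound 3 ((morpholin-4-yl)carbonyl in place of (piperidin-1-yl)methyl on a saturated chain carbon bound to an amide-type nitrogen) in carrying (morpholin-4-yl)carbonyl in place of (piperidin-1-yl)methyl on a saturated chain carbon bound to an amide-type nitrogen.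

Within the data shown here, no measured step tests this exact swap, so the expectation is loose. The nearest evidence is a 5.1-fold lower number from compound 2 to compound 3 (0.70 log units; beyond the scatter) and an 8.6-fold lower number from compound 1 to compound 3 (0.93 log units; beyond the scatter) on introducing the (2-(piperidin-1-yl)ethyl)amino group, whereas a 1.7-fold lower number from compound 1 to compound 2 (0.23 log units; within the scatter) separates the two compounds without it. Since compound 4 gives up that piperidine-bearing end, a modest step to a higher number is expected in this assay rather than a further fall. The expected change is a 4.0-fold higher number from compound 3 to compound 4 (0.60 log units; beyond the scatter) in this reading. Compound 4 is estimated at 600 nM with a range from 200 nM to 1800 nM in this measurement.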

Compound 4, half-maximal inhibitory concentration: 490 nM
For compound 4 the middle estimate is 1.2-fold (0.09 log units) above the measured one, and the stated range covers the measured number.
By their numbers in this assay, from the lowest: compound 3; then compounds 4, 2 and 1 (each within the scatter of the next, the first and the last beyond it).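

Compound 4 shows that a six-membered non-aromatic ring carried on this chain does not by itself keep the low number of compound 3 in this assay: putting (morpholin-4-yl)carbonyl in place of (piperidin-1-yl)methyl gives a 3.3-fold higher number from compound 3 to compound 4 (0.51 log units; beyond the scatter). Against the smaller groups on the carbonyl carbon the picture divides, with a 2.6-fold lower number from compound 1 to compound 4 (0.42 log units; beyond the scatter) but only a 1.6-fold lower number from compound 2 to compound 4 (0.19 log units; within the scatter), so compound 4 cannot be told apart from compound 2. Nothing measured on these compounds accounts for the step.

The swap changes the ring and the carbonyl link together, so the compounds shown leave open which of the two carries the step. A (morpholin-4-yl)methyl group or a (piperidin-1-yl)carbonyl group on the same chain carbon would separate the two changes.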